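From diethylamino to a pyrrolidine side chain

The source may hold more compounds than are shown below. What is called first, only, known or untested is meant among the compounds shown, and "the series" means these compounds.

In a functional assay on SK-BR-3 cells (Homo sapiens) for antiproliferative activity, read by MTT assay, with a stated time of 72 h (on this read-out lower numbers stand for stronger inhibition and higher numbers for weaker inhibition), compound 3 (`CCN(CC)c1cc(C)c2cc(NC(=O)c3ccc(Cl)c(Cl)c3)ccc2n1`) gives 41200 nM and lies within the scatter of compound 2 (`CCN1CCN(c2cc(C)c3cc(NC(=O)c4ccccc4F)ccc3n2)CC1`), which gives 38100 nM on the same read-out. Compound 1 (`CNc1cc(C)c2cc(NC(=O)c3ccc(Cl)c(Cl)c3)ccc2n1`) gives the lower number of 6350 nM in this assay here. Compound 4 (`Cc1cc(NCCN2CCCC2)nc2ccc(NC(=O)c3ccc(Cl)c(Cl)c3)cc12`) carries (2-(pyrrolidin-1-yl)ethyl)amino in place of the diethylamino of compound 3, on an aromatic carbon next to the ring nitrogen ((2-(pyrrolidin-1-yl)ethyl)amino in place of diethylamino on an aromatic carbon). For the measured compounds named here, the one measured step at this place is a 6.5-fold higher number from compound 1 to compound 3 (0.81 log units; beyond the scatter) with diethylamino in place of methylamino, a modest change. Going by the values given here, compound 2 differs from the others in more than one place and offers no clean step. Like the methylamino of compound 1 (6350 nM), the entering group keeps a hydrogen on the nitrogen joined to the core, though no measured compound carries its chain and ring. A move back toward a lower number is therefore expected, and the expected step is a 5.2-fold lower number from compound 3 to compound 4 (0.71 log units; beyond the scatter) in this assay with wide uncertainty. For compound 4 the estimated value is 8000 nM with an expected range from 2000 nM to 30000 nM in this assay.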

Compound 4, half-maximal inhibitory concentration: 9530 nM
For compound 4 the middle estimate is 1.2-fold (0.08 log units) below the measured one; measured number inside the range.
By their numbers in this assay, from the lowest: compounds 1 and 4 (each within the scatter of the next); then compounds 2 and 3 (each within the scatter of the next).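

In this assay the change to (2-(pyrrolidin-1-yl)ethyl)amino gives a 4.3-fold lower number from compound 3 to compound 4 (0.64 log units; beyond the scatter), so this position next to the ring nitrogen accepts a chain ending in a five-membered non-aromatic ring without the number rising over that of diethylamino. Set against the methylamino group, the same chain and ring give a 1.5-fold higher number from compound 1 to compound 4 (0.18 log units; within the scatter), so they cannot be told apart from that small group on this read-out. Among these three compounds, the two with a hydrogen on the nitrogen joined to the core share the lower numbers and compound 3, without that hydrogen, has the higher one, but no measurement here explains this link.

As far as these compounds go, it remains open whether an unsubstituted amino group would fit the same pattern. From the compounds shown here alone, the effect of a morpholine in place of the pyrrolidine, or of a longer chain leading to it, also remains open.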